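This account rests on a few compounds, and the source may have more. Where it says the series, first, only, none or still open, it means among the compounds named here.

Measured so far:

- compound 1 `O=C1/C(=C/c2coc3ccccc3c2=O)N=C(c2ccccc2)N1c1ccc(S(=O)(=O)Nc2ncccn2)cc1`: > 100000 nM
- compound 2 `Cc1cc(C)nc(NS(=O)(=O)c2ccc(NC3=NC(=O)/C(=C\c4coc5ccccc5c4=O)S3)cc2)n1`: > 100000 nM
- compound 3 `CCOC1Oc2ccccc2C(=O)/C1=C/Nc1ccc(S(=O)(=O)Nc2ncccn2)cc1`: 30100 nM

All three values come from a functional assay on MCF7 cells (Homo sapiens) for cytotoxicity, read by sulforhodamine B assay, with a stated time of 72 h; on this read-out higher numbers stand for weaker inhibition and lower numbers for stronger inhibition. For compound 1 the read-out is not a number but a limit: in this assay compound 1 gives > 100000 nM. Compound 2 also stops at a limit, giving > 100000 nM in this assay. Only compound 3 returns a measured number, 30100 nM in this assay. So compound 1 stands at the limit of > 100000 nM in this assay, at which 2 of the 3 values shown sit, and no ranking against the other two can be read from that.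

The next compound, compound 4 `O=C1/C(=C/c2coc3ccccc3c2=O)N=C(c2ccccc2)N1c1ccc(S(=O)(=O)Nc2ccccn2)cc1`, keeps everything in compound 1 except the group on the sulfonamide nitrogen:

pyridin-2-yl in place of pyrimidin-2-yl on a sulfonamide nitrogen

Going by the values given here, no measured pair among the three compounds shows such a change, so its effect is not known from these data. With compound 1 sitting at a limit, the most that can be said is that a change of this size is expected to give no step beyond the scatter, and most likely another limit. The step from compound 1 to compound 4 is expected to be a step that the limit leaves unreadable from compound 1 to compound 4. For compound 4 the estimate in this assay is 150000 nM, with a range from 50000 nM to 500000 nM.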

Compound 4, half-maximal inhibitory concentration: > 100000 nM
Compound 4: only a limit was reported; the forecaster's own chance of this, stated with the estimate: 75%; the middle value lies beyond the limit too.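

In this assay, compound 1 and compound 4 both stop at a limit rather than a number, so no step between them can be read: the limit of > 100000 nM in this assay, at which 3 of the 4 values shown sit.

The compounds shown leave open whether pyridin-2-yl in place of pyrimidin-2-yl on a sulfonamide nitrogen changes the read-out at all.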